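The source may hold more compounds than are shown below. What is called first, only, known or untested is meant among the compounds shown, and "the series" means these compounds.

Compound 1 `Cc1cccc(N2C(=O)CSC2c2cccc(C(=O)NCCCCc3ccccc3)c2)c1` and compound 2 `COc1cc(F)ccc1N1C(=O)CSC1c1cccc(C(=O)NCCCCc2ccccc2)c1` share one core and differ only in the aryl group carried on an amide-type nitrogen in a ring. In a functional assay on HOS-TE85 cells (Homo sapiens) for inhibition, read by CCK-8 assay, with a stated time of 72 h (on this read-out lower numbers stand for stronger inhibition and higher numbers for weaker inhibition), compound 1 gives 93.2 nM, and in the same setting compound 2 gives 71.1 nM. The change between them produced a 1.3-fold lower number from compound 1 to compound 2 (0.12 log units; within the scatter). Within the data shown here, compound 2 therefore holds the lower of the two numbers measured so far, but because the step of a 1.3-fold lower number from compound 1 to compound 2 (0.12 log units; within the scatter) lies within the scatter, the two compounds cannot really be told apart on this evidence.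

Compound 3 `COc1cccc(OC)c1N1C(=O)CSC1c1cccc(C(=O)NCCCCc2ccccc2)c1` has not yet been measured. It differs from compound 2 by 2,6-dimethoxyphenyl in place of 4-fluoro-2-methoxyphenyl on an amide-type nitrogen in a ring. Among the measured compounds shown here, only one measured step bears on this kind of change, the swap of the group on the amide-type nitrogen in a ring, and that step, a 1.3-fold lower number from compound 1 to compound 2 (0.12 log units; within the scatter), stayed within the scatter. With a single, flat comparison to go on, no shift beyond the scatter is expected in this assay. Compound 3 is therefore expected to give 75 nM, within a likely range from 30 nM to 190 nM. The expected step of a 1.1-fold higher number from compound 2 to compound 3 (0.02 log units; within the scatter) is thus one that stays within the scatter.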

Compound 3, half-maximal inhibitory concentration: > 1000 nM
Compound 3: a limit, no number; the forecaster's own chance of this, stated with the estimate: 2%; at least 13-fold (1.12 log units) between middle value and limit.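

In this assay, compound 3 carries a limit of the assay and not a number: the limit of > 1000 nM in this assay, at which 1 of the 3 values shown sits. Even so, the swap on the amide-type nitrogen in a ring is no longer flat, since 2,6-dimethoxyphenyl gives an at least 14-fold higher number from compound 2 to compound 3 (1.14 log units; beyond the scatter) and an at least 10-fold higher number from compound 1 to compound 3 (1.03 log units; beyond the scatter), both large and beyond the scatter. The earlier pair showed only that 3-methylphenyl and 4-fluoro-2-methoxyphenyl could not be told apart at this position, while compound 3 shows that the position does not accept every aryl group and that the choice of group here can cost much of the inhibition seen with compound 1 and compound 2.

The compounds shown leave open which part of the change carries the step, since going from compound 2 to compound 3 removes the fluorine and adds a second methoxy at once, and the limit hides how large the full step is. Compounds with 2-methoxyphenyl or 2,6-dimethylphenyl on the same nitrogen would help to separate the loss of the fluorine from the gain of the second methoxy.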